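From acid to methyl ester at the assay limit

The source may report more compounds than this note shows. Statements on the series, on what has been measured and on what is new or still open speak of the compounds shown alone.

Of the compounds shown here, three have been tested in a functional assay on cells (Platelet, Homo sapiens) for inhibition; a higher number here means a weaker inhibitor, a lower number a stronger inhibitor: compound 1 (`CCOC(=O)c1ccc(-c2nn(C)c3ccccc23)cc1`), compound 2 (`CCOC(=O)c1ccc(-c2nn(Cc3ccc(OC)cc3)c3ccccc23)cc1`) and compound 3 (`O=C(O)c1ccc(-c2nn(Cc3ccccc3)c3ccccc23)cc1`). Compound 3 gives > 10000 nM, which is a limit of the assay and not a number. Compound 1 gives > 10000 nM, also a limit. Compound 2 gives > 10000 nM, again a limit. For the measured compounds named here, the position so far is the limit of > 10000 nM in this assay, at which 3 of the 3 values shown sit.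

Compound 4 (`COC(=O)c1ccc(-c2nn(Cc3ccccc3)c3ccccc23)cc1`) is the next to be measured. Its change from compound 3 is methyl in place of hydrogen on an oxygen next to a carbonyl group, so that carboxy becomes methoxycarbonyl. Going by the values given here, the one measured step, a step that the two limits leave unreadable from compound 1 to compound 2, lies at a different place and gives no size. Compound 1 and compound 2 already carry an ester, yet neither yields a number, so the data offer no measured size for this change. Any shift would be expected towards stronger inhibition, and a further reading at the limit remains quite possible. The step expected is an at least 1.2-fold lower number from compound 3 to compound 4 (0.09 log units; that floor lies within the scatter), an estimate with little support. For compound 4 the estimated value is 8000 nM, with an expected range of 1000 nM to 30000 nM.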

Compound 4, half-maximal inhibitory concentration: > 10000 nM
Compound 4: no number, only a limit; the forecaster's own chance of this, stated with the estimate: 50%; at least 1.2-fold (0.09 log units) between middle value and limit.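

Compound 4 gives > 10000 nM in this assay and this is a limit, not a number. Compound 3 also stands at a limit, so no step can be read between compound 3 and compound 4. The position is unchanged: the limit of > 10000 nM in this assay, at which 4 of the 4 values shown sit. The compounds shown leave open which change, if any, would bring a measurable value in this assay.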